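Chloro on the Core and Cell Toxicity

The source may report more compounds than this note shows. Statements on the series, on what has been measured and on what is new or still open speak of the compounds shown alone.

Measured compounds:
compound 1, `N#Cc1ccc(Nc2nc(Oc3ccc(F)cc3)c3ccccc3n2)cc1`: > 351000 nM
compound 2, `Cc1cc(C#N)cc(C)c1Oc1nc(Nc2ccc(C#N)cc2)nc2ccccc12`: 203000 nM

In an ADME assay on MT4 cells (Homo sapiens) for cytotoxicity, read by MTT assay, with a stated time of 4 days (on this read-out higher numbers stand for lower toxicity in this test and lower numbers for higher toxicity in this test), compound 1 gives > 351000 nM, which is a limit of the assay rather than a number. Among the measured compounds shown here, compound 2 gives 203000 nM in this assay, the only plain number among the two values shown; the other value sits at the limit of > 351000 nM in this assay, at which 1 of the 2 values shown sits. For the measured compounds named here, the single measured step, an at least 1.7-fold lower number from compound 1 to compound 2 (0.23 log units; that floor lies within the scatter), concerns the ring on the oxygen.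

Compound 3, `Cc1cc(C#N)cc(C)c1Oc1nc(Nc2ccc(C#N)cc2)nc2ccc(Cl)cc12`, differs from compound 2 by chloro in place of hydrogen on an aromatic carbon. Going by the values given here, no measured step touches this part of the shared core, so none of the measured steps bears directly on it, and the one step that does exist sits within the scatter. The expectation in this assay is therefore a step of no size beyond the scatter. The expected step is a 1.0-fold lower number from compound 2 to compound 3 (0.01 log units; within the scatter). Compound 3 is estimated to give 200000 nM in this assay, with a range from 80000 nM to 400000 nM.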

Compound 3, half-maximal cytotoxic concentration: 117000 nM
Beside the measured number, compound 3's estimate is 1.7-fold (0.23 log units) above it; the range from low to high includes it.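

Among the compounds shown here, this is the first step that touches the shared core itself rather than the ring on the oxygen. In this assay, chloro in place of hydrogen on an aromatic carbon of the fused system gives a 1.7-fold lower number from compound 2 to compound 3 (0.24 log units; within the scatter) and so leaves compound 2 and compound 3 indistinguishable. Unlike the earlier step, which rested on a limit, this one joins two plain numbers, so its size can be read directly, and nothing at hand offers an explanation for it.

The compounds shown leave open whether bromo, an amine or a carboxylic acid on this same carbon would give a step beyond the scatter. Also open, going by these compounds, is whether chloro on another carbon of the core, or on a core carrying the 4-fluorophenyl of compound 1, would read the same way.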